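Working notes: phenyl in place of methyl, compound 4

The source may report more compounds than this note shows. Statements on the series, on what has been measured and on what is new or still open speak of the compounds shown alone.

Values in a functional assay on A549 cells (Homo sapiens) for inhibition, read by MTT assay, with a stated time of 72 h (a higher number here means a weaker inhibitor, a lower number a stronger inhibitor), are as follows.
- Compound 1 `COC(=O)c1ccc(-n2cc(CCCNC(=S)c3ccc(C)cc3)nn2)cc1` gives > 100000 nM as a limit only.
- Compound 2 `COC(=O)c1ccc(-c2cn(CCCC(=O)Nc3ccc(C)cc3)nn2)cc1` gives > 100000 nM as a limit only.
- Compound 3 `Cc1ccc(NC(=O)CCCn2cc(-c3ccc(C(F)(F)F)cc3)nn2)cc1` gives 25000 nM as a measured number.

Compound 2 stands at > 100000 nM and this is a limit, so there is no number from which to count a step. Among the compounds with values here, the series so far is thin, and its main feature is the limit of > 100000 nM in this assay, at which 2 of the 3 values shown sit, as the place where most values sit.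

Compound 4 `COC(=O)c1ccc(-c2cn(CCCC(=O)Nc3ccc(-c4ccccc4)cc3)nn2)cc1` differs from compound 2 at one place only. The change is phenyl in place of methyl on an aromatic carbon and in words it is phenyl in place of methyl on an aromatic carbon, para to a large group.

One measured step is available, an at least 4.0-fold lower number from compound 2 to compound 3 (0.60 log units; beyond the scatter) (trifluoromethyl in place of methoxycarbonyl on an aromatic carbon). It lies at a different place in the molecule, so it bears only indirectly, showing that compound 3 gives a number where compound 2 does not. Within the data shown here, no measured step touches the methyl that leaves. A modest move to a lower number in this assay is therefore the expected direction, and staying at the limit is about as likely.

The expected change is estimated as an at least 2.0-fold lower number from compound 2 to compound 4 (0.30 log units; that floor lies within the scatter) in this assay and it carries wide uncertainty.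

Compound 4 is expected at 50000 nM (estimated range 15000 nM to 100000 nM) in this assay as the working estimate.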

Compound 4, half-maximal inhibitory concentration: 330 nM
For compound 4 the middle estimate is 150-fold (2.18 log units) above the measured one, outside the stated range (below it).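

In this assay, within the data shown here, phenyl in place of methyl on an aromatic carbon, para to a large group, gives an at least 300-fold lower number from compound 2 to compound 4 (2.48 log units; beyond the scatter), the first measured step at this position. Methoxycarbonyl is present in both compounds of this step, so its presence alone does not hold a compound at the limit, something compound 3 could not show, as it carries trifluoromethyl at that place. The step is a floor rather than a full size, and values at a limit remain common in this short series: the limit of > 100000 nM in this assay, at which 2 of the 4 values shown sit.

The compounds shown leave open whether an aromatic ring is needed at this position, or whether a saturated ring such as cyclohexyl, or a branched group such as tert-butyl, would serve as well as phenyl. Also open, going by these compounds, is whether phenyl in place of methyl would lower the number in the same way in compound 3, which carries the same methyl alongside trifluoromethyl at the far end of the molecule.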